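The compounds below may be only part of what the source reports. "The series", "measured", "known", "first", "only" and "open" are said of these compounds alone.

Three compounds that share one core and differ only in the group on a sulfonyl sulfur have been measured in a functional assay on A2780 cells (Homo sapiens) for antiproliferative activity, read by sulforhodamine B assay, with a stated time of 72 h; on this read-out higher numbers stand for weaker inhibition and lower numbers for stronger inhibition. Compound 1 `N#C/N=C(\NCc1ccc(S(=O)(=O)c2ccccc2)cc1)Nc1ccncc1` gives 9.7 nM. Compound 2 `N#C/N=C(\NCc1ccc(S(=O)(=O)N2CC3CCC(C2)O3)cc1)Nc1ccncc1` gives 50 nM. Compound 3 `N#C/N=C(\NCc1ccc(S(=O)(=O)c2cccc3cccnc23)cc1)Nc1ccncc1` gives 14 nM. Compound 3 thus stands level with compound 1 within the scatter, as the measured step shows: a 1.4-fold higher number from compound 1 to compound 3 (0.16 log units; within the scatter). Compound 2 sits apart from both, seen in a 5.2-fold higher number from compound 1 to compound 2 (0.71 log units; beyond the scatter) and in a 3.6-fold lower number from compound 2 to compound 3 (0.55 log units; beyond the scatter).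

The next compound is compound 4 `N#C/N=C(\NCc1ccc(S(=O)(=O)c2cccc(OC(F)(F)F)c2)cc1)Nc1ccncc1`, which carries 3-(trifluoromethoxy)phenyl in place of quinolin-8-yl on a sulfonyl sulfur. Within the data shown here, the closest precedent is the exchange between phenyl and quinolin-8-yl in compound 1 and compound 3, where a 1.4-fold higher number from compound 1 to compound 3 (0.16 log units; within the scatter) stayed within the scatter. The two larger steps both involve compound 2, whose group has no aromatic ring, so they bear less on this change. Among the measured compounds shown here, no measured compound carries a substituted phenyl, which leaves the effect of the new group untested. No step beyond the scatter is therefore expected in this assay. The step expected is a 1.2-fold lower number from compound 3 to compound 4 (0.07 log units; within the scatter). For compound 4 the estimated value is 12 nM, with an expected range of 4 nM to 35 nM.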

Compound 4, half-maximal inhibitory concentration: 2.2 nM
Compound 4: middle estimate off by 5.5-fold (0.74 log units), on the high side, and the stated range ends above it.
By their numbers in this assay, from the lowest: compound 4; then compounds 1 and 3 (each within the scatter of the next); then compound 2.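

In this assay, among these compounds, the aromatic group on the sulfonyl sulfur turns out to matter more than the earlier compounds suggested: trifluoromethoxy in place of hydrogen on an aromatic carbon gives a 4.4-fold lower number from compound 1 to compound 4 (0.64 log units; beyond the scatter), whereas the exchange of phenyl for quinolin-8-yl had stayed within the scatter. The exchange of quinolin-8-yl for 3-(trifluoromethoxy)phenyl likewise gives a 6.4-fold lower number from compound 3 to compound 4 (0.80 log units; beyond the scatter), so a single substituent on the phenyl ring separates compound 4 from both of the other aromatic sulfones, and it stands as the most potent of the four. The gap to the one group without an aromatic ring also grows to a 23-fold lower number from compound 2 to compound 4 (1.36 log units; beyond the scatter), the only large step in the set, although no measurement shown here offers a reason for any of these differences.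

The compounds shown leave open whether this gain belongs to trifluoromethoxy itself or would also appear with methoxy, trifluoromethyl or a chlorine atom on the same phenyl ring. They also leave open whether trifluoromethoxy on the quinolin-8-yl group would give a similar step, and whether a simple amine such as piperidine on the sulfonyl sulfur would match the number of compound 2.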